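The source may report more compounds than this note shows. Statements on the series, on what has been measured and on what is new or still open speak of the compounds shown alone.

Compound 1 `COc1ccc(-n2c(=O)n(Cc3cc4cc(Cl)ccc4n3CCCC#N)c3cnccc32)cc1OC` and compound 2 `CS(=O)(=O)c1ccc(-n2c(=O)n(Cc3cc4cc(Cl)ccc4n3CCCC#N)c3cnccc32)cc1` share one core and differ only in the group carried on an aromatic nitrogen. In an ADME assay on HeLa cells (Homo sapiens) for cytotoxicity, read by ATP content, with a stated time of 3 days (on this read-out higher numbers stand for lower toxicity in this test and lower numbers for higher toxicity in this test), compound 1 gives > 50000 nM, which is a limit of the test and not a number. In this assay compound 2 likewise gives > 50000 nM, again a limit rather than a number. The step that the two limits leave unreadable from compound 1 to compound 2 therefore cannot be read, because the limit of > 50000 nM in this assay, at which 2 of the 2 values shown sit, places both values at the same limit. Compound 2 stands at that limit, where every value shown so far sits.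

Compound 3 `N#CCCCn1c(Cn2c(=O)n(-c3ccncn3)c3ccncc32)cc2cc(Cl)ccc21` differs from compound 2 by pyrimidin-4-yl in place of 4-(methylsulfonyl)phenyl on an aromatic nitrogen. Among the compounds with values here, no measured step bears on this exchange in a readable way, since the only step on hand, from a 3,4-dimethoxyphenyl to a 4-(methylsulfonyl)phenyl, is hidden by two limits. The expectation for compound 3 in this assay therefore rests only on both measured compounds sitting at the limit, and the step that the limit leaves unreadable from compound 2 to compound 3 is expected to stay within the scatter. Compound 3 is estimated at 60000 nM, with a range from 20000 nM to 200000 nM.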

Compound 3, half-maximal cytotoxic concentration: > 50000 nM
Compound 3: a limit, no number; the forecaster's own chance of this, stated with the estimate: 85%; the middle value does not contradict the limit.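

In this assay compound 3 gives > 50000 nM, a limit and not a number. No step among compound 1, compound 2 and compound 3 can therefore be read: the limit of > 50000 nM in this assay, at which 3 of the 3 values shown sit.

The compounds shown leave open whether the group on the aromatic nitrogen changes the half-maximal cytotoxic concentration in this assay at all, and by how much.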